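Aryl ether change from compound 2 to compound 4

This account rests on a few compounds, and the source may have more. Where it says the series, first, only, none or still open, it means among the compounds named here.

Working notes on the series. Compound 1 `Cc1ccccc1OCc1cn(-c2ccc(S(=O)(=O)N3CCc4ccccc4C3)cc2)nn1` carries the 2-methylphenoxy group on its core. In a functional assay on MOLT-3 cells (Homo sapiens) for cytotoxicity, read by MTT assay, with a stated time of 48 h (a higher number here means a weaker inhibitor, a lower number a stronger inhibitor), compound 1 gives > 50 ug/mL, which is a limit of the assay and not a number. Compound 3 `O=S(=O)(c1ccc(-n2cc(COc3ccccc3)nn2)cc1)N1CCc2ccccc2C1` differs by hydrogen in place of methyl on an aromatic carbon. In this assay compound 3 gives > 50 ug/mL, again a limit. The step that the two limits leave unreadable from compound 1 to compound 3 is therefore not readable.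

Compound 2 `COc1cc2c(cc1OC)CN(S(=O)(=O)c1ccc(-n3cc(COc4ccc([N+](=O)[O-])cc4)nn3)cc1)CC2` carries the 4-nitrophenoxy group on the other core. In this assay compound 2 gives > 50 ug/mL, also a limit. Where compound 2 stands is thus only a limit, as for every measured value here: the limit of > 50 ug/mL in this assay, at which 3 of the 3 values shown sit.

Compound 4 `COc1cc2c(cc1OC)CN(S(=O)(=O)c1ccc(-n3cc(COc4ccccc4C)nn3)cc1)CC2` has not been measured. The change is 2-methylphenyl in place of 4-nitrophenyl on an oxygen on a saturated carbon. Among the compounds with values here, no measured step matches this change; the only measured step, from compound 1 to compound 3, is itself unreadable between two limits. The 2-methylphenoxy end already sits at the limit in compound 1, and the 4-nitrophenoxy end sits at the limit in compound 2, so no readable step beyond the scatter in this assay is expected. Compound 4 is expected to give 90 ug/mL, with a range from 50 ug/mL to 200 ug/mL. The expected step that the limit leaves unreadable from compound 2 to compound 4 is accordingly no readable change.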

Compound 4, half-maximal inhibitory concentration: > 50 ug/mL
Compound 4 gave a limit, no number (the forecaster's own chance of this, stated with the estimate: 85%); the middle value is on the limit's open side.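

In this assay compound 4 gives > 50 ug/mL, a limit and not a number, so no step can be read from compound 2 to compound 4. The series stands at a single limit: the limit of > 50 ug/mL in this assay, at which 4 of the 4 values shown sit.

The compounds shown leave open whether any aryl ether on either core gives a readable value in this assay.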